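A few compounds are considered here, and "the series" means these few. Any claim that something is new, unique, unknown or untested is made for them only; others in the source may bear on it.

Three compounds have been measured in a functional assay on A549 cells (Homo sapiens) for antiproliferative activity, read by MTT assay, with a stated time of 48 h; on this read-out higher numbers stand for weaker inhibition and lower numbers for stronger inhibition:

compound 1, `COc1cc(-c2cccc3nc(-c4ccccc4)oc23)cc(OC)c1OC`, gives 20300 nM
compound 2, `COc1cccc(-c2nc3cccc(-c4cc(OC)c(OC)c(OC)c4)c3o2)c1`, gives 3500 nM
compound 3, `COc1cc(-c2cccc3nc(-c4cccc(F)c4)oc23)cc(OC)c1OC`, gives 2600 nM

Compound 1 stands at the highest number of the three, which on this read-out means the weakest inhibition; compound 2 is the nearest to it and compound 3 the furthest away.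

Compound 4, `COc1cc(-c2cccc3nc(-c4ccc(F)cc4)oc23)cc(OC)c1OC`, has not yet been measured. It differs from compound 1 in one place: fluoro in place of hydrogen on an aromatic carbon. The change that bears most directly on it is the step of a 7.8-fold lower number from compound 1 to compound 3 (0.89 log units; beyond the scatter), where the same fluoro enters the same ring, only at a different position on it. The step of a 5.8-fold lower number from compound 1 to compound 2 (0.76 log units; beyond the scatter) points the same way, showing that adding a single small group to that ring has so far lowered the number each time. Among the measured compounds shown here, only two such steps exist, both from the same starting compound, so the expected effect is carried over from them rather than from any broader rule.

On that basis compound 4 is expected to give a lower number than compound 1, by roughly a 5.8-fold lower number from compound 1 to compound 4 (0.76 log units; beyond the scatter). The estimate for compound 4 in this assay is 3500 nM, with a range from 1000 nM to 12000 nM.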

Compound 4, half-maximal inhibitory concentration: 8700 nM
For compound 4 the middle estimate is 2.5-fold (0.40 log units) below the measured one, and the stated range covers the measured number.
By their numbers in this assay, from the lowest: compounds 3 and 2 (each within the scatter of the next); then compound 4; then compound 1.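

In this assay, fluoro para to a large group still lowers the number, with a 2.3-fold lower number from compound 1 to compound 4 (0.37 log units; beyond the scatter), so the gain seen on adding a small group to this ring also appears at this new position, though here it is smaller. Where the fluoro sits on the ring clearly matters, since a 3.3-fold higher number from compound 3 to compound 4 (0.52 log units; beyond the scatter) is beyond the usual scatter even though the two compounds hold the same atoms, and a 2.5-fold higher number from compound 2 to compound 4 (0.40 log units; beyond the scatter) shows that the 3-methoxyphenyl compound also gives a lower number than the 4-fluorophenyl one. No measurement in hand explains why moving the fluoro changes the number in this way.

Among the compounds shown here, what remains open is whether this position favours only fluoro or also takes other groups, such as a chloro, a methoxy or an amine, which could give a number on either side of the one for compound 4. As far as these compounds go, it is equally open whether a larger group here, such as a carboxylic acid or a longer alkyl chain, would keep any of the gain over compound 1.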